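From Bromo to Sulfamoyl in a Weakly Cytotoxic Series

The source may hold more compounds than are shown below. What is called first, only, known or untested is meant among the compounds shown, and "the series" means these compounds.

Three compounds were tested in a functional assay on RKO cells (Homo sapiens) for cytotoxicity, read by resazurin assay, with a stated time of 72 h; a lower number here means a stronger inhibitor, a higher number a weaker inhibitor. Compound 1 `Cc1ccc(Nc2nc(-n3ccnc3C)cs2)cc1` gives no number, only the limit of the measurement, at > 100000 nM. Compound 3 `c1ccc(Nc2nc(-n3cnc4ccccc43)cs2)cc1` likewise stops at the limit, giving > 100000 nM. Together compounds 1 and 3 mark (the limit of > 100000 nM in this assay, at which 2 of the 3 values shown sit). For the measured compounds named here, compound 2 `Cc1nc2ccccc2n1-c1csc(Nc2ccc(Br)cc2)n1` is the only one with a number in this assay, 60000 nM, and that is still a weak one. Compound 4 `Cc1nc2ccccc2n1-c1csc(Nc2ccc(S(N)(=O)=O)cc2)n1` carries a sulfamoyl in place of the bromo of compound 2 (sulfamoyl in place of bromo on an aromatic carbon). Going by the values given here, no measured pair shows what such a swap does here, so the expected step is small, within the scatter. In this assay compound 4 is estimated at 70000 nM, with a range from 20000 nM to 250000 nM. The step expected is a 1.2-fold higher number from compound 2 to compound 4 (0.07 log units; within the scatter).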

Compound 4, half-maximal inhibitory concentration: 95000 nM
Estimate against measurement, compound 4: 1.4-fold (0.13 log units) below; measured number inside the range.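

For the compounds shown here, this is the first measured pair at this position: in this assay, sulfamoyl in place of bromo gives a 1.6-fold higher number from compound 2 to compound 4 (0.20 log units; within the scatter). A larger group that brings a hydrogen-bond donor and acceptors, where bromo has neither, therefore leaves the reading unchanged within the scatter. Both numbers are weak and sit close to the top of what the assay reports, which leaves little room to read any change: the limit of > 100000 nM in this assay, at which 2 of the 4 values shown sit.

Still open, on these data alone, is whether an amine or a carboxylic acid on this aromatic carbon would give a number clearly apart from these two. The compounds shown also do not tell whether any group here can give a strong inhibitor.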